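A few compounds are considered here, and "the series" means these few. Any claim that something is new, unique, unknown or untested is made for them only; others in the source may bear on it.

Working notes on the series. In an ADME assay on HT-29 cells (Homo sapiens) for cytotoxicity, read by MTT assay, with a stated time of 72 h (on this read-out higher numbers stand for weaker inhibition and lower numbers for stronger inhibition), compound 1 `C=CCOc1cc(C2=C(c3cc(OC)c(OC)c(OC)c3)C(=O)C(O)C2)ccc1OC` gives > 100 ug/mL, which is a limit and not a number. Compound 2 `COc1cc(C2=C(c3cc(C)c(OC)c(C)c3)C(OC(C)=O)CC2=O)cc(OC)c1OC` gives > 100 ug/mL, also a limit. Compound 3 `COc1ccc(C2=C(c3cc(OC)c(OC)c(OC)c3)C(=O)CC2O[SiH2]C(C)(C)C)cc1OC` gives > 100 ug/mL, again a limit. Compound 1 therefore stands with the other two at the limit of > 100 ug/mL in this assay, at which 3 of the 3 values shown sit, and no ranking can be drawn among them.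

Compound 4 `COc1ccc(C2=C(c3cc(OC)c(OC)c(OC)c3)C(=O)C(O)C2)cc1F` keeps the core of compound 1 and carries fluoro in place of allyloxy on an aromatic carbon, ortho to a methoxy group: fluoro in place of allyloxy on an aromatic carbon. For the measured compounds named here, no measured pair differs in one place, so the size of the step has no direct precedent. In this assay, the expected direction is toward stronger inhibition, though a reading that stays at the limit remains quite possible. The estimated step is an at least 5.0-fold lower number from compound 1 to compound 4 (0.69 log units; beyond the scatter), and its size is uncertain. For compound 4 the expected value is 20 ug/mL, with an estimated range of 0.5 ug/mL to 100 ug/mL.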

Compound 4, half-maximal inhibitory concentration: < 1 ug/mL
Compound 4: no number, only a limit (the forecaster's own chance of this, stated with the estimate: 40%); at least 20-fold (1.30 log units) between middle value and limit.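

In this assay, for the compounds shown here, fluoro in place of allyloxy on this aromatic carbon, ortho to a methoxy group, gives an at least 100-fold lower number from compound 1 to compound 4 (2.00 log units; beyond the scatter), the first step that can be read. Going by these compounds alone, it shows that this one change moves the read-out, which the earlier compounds could not show, all sitting at one limit: the limit of > 100 ug/mL in this assay, at which 3 of the 4 values shown sit. The reading of compound 4 is likewise a limit and not a number, and it stands alone there: the limit of < 1 ug/mL in this assay, at which 1 of the 4 values shown sits.

On these data alone, with a limit at each end, the true size of the step stays open, as does whether fluoro itself is needed or the removal of allyloxy is enough. As far as these compounds go, whether hydrogen, chloro or an amine on this carbon would read like fluoro or like allyloxy also remains open.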